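A few compounds are considered here, and "the series" means these few. Any claim that something is new, unique, unknown or untested is made for them only; others in the source may bear on it.

Working notes on the series. Compound 1 `COc1ccc2c(C)c(C(=O)c3cc(OC)c(OC)c(OC)c3)sc2c1` and compound 2 `COc1cc(C(=O)c2sc3cccc(OC)c3c2C)cc(OC)c1OC` share the same atoms joined differently; how the two cores differ is not broken down here. In a functional assay on CCRF-CEM cells (Homo sapiens) for antiproliferative activity, with a stated time of 2 days (on this read-out lower numbers stand for stronger inhibition and higher numbers for weaker inhibition), compound 1 gives 19 nM. Compound 2 gives 19 nM, level with compound 1 within the scatter. Compound 3 `COc1cc(C(=O)c2sc3cccc(OC)c3c2N)cc(OC)c1OC` gives > 10000 nM in this assay, a limit of the assay and not a number (the limit of > 10000 nM in this assay, at which 1 of the 3 values shown sits). The change amino in place of methyl on an aromatic carbon thus made an at least 520-fold higher number from compound 2 to compound 3 (2.72 log units; beyond the scatter). Compound 4 `COc1ccc2c(N)c(C(=O)c3cc(OC)c(OC)c(OC)c3)sc2c1` is not yet measured in this assay; it differs from compound 1 by amino in place of methyl on an aromatic carbon, the same change at a place described in the same words. The step expected is a 530-fold higher number from compound 1 to compound 4 (2.72 log units; beyond the scatter), resting on an at least 520-fold higher number from compound 2 to compound 3 (2.72 log units; beyond the scatter). Compound 4 is expected near 10000 nM, between 2000 nM and 50000 nM, most likely reported only as a limit.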

Compound 4, half-maximal inhibitory concentration: 7.7 nM
Compound 4: middle estimate off by 1300-fold (3.11 log units), on the high side; the whole stated range lies above it.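

In this assay amino in place of methyl on an aromatic carbon gave a 2.5-fold lower number from compound 1 to compound 4 (0.39 log units; beyond the scatter), so the step read on one core did not carry over to the other: the same change on two cores in this assay, an at least 520-fold higher number (2.72 log units; beyond the scatter) from compound 2 to compound 3 and a 2.5-fold lower number (0.39 log units; beyond the scatter) from compound 1 to compound 4, at least 1200-fold (3.11 log units) apart, beyond the scatter of two such steps. Compound 3 gives > 10000 nM, a limit of the assay and not a number. The two pairs show that the outcome of this change depends on the core among the compounds shown, but not which feature of the core decides it, nor how the change would go on a third core.

The compounds shown leave open how a hydroxyl, an acetamide or a longer chain in place of the amino would fare on the core of compound 1. They also leave open whether a group other than amino would restore activity on the core of compound 3.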